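Carboxy on the propyl chain of compound 3

The source may hold more compounds than are shown below. What is called first, only, known or untested is meant among the compounds shown, and "the series" means these compounds.

Measured in an ADME assay on MDCK cells (Canis lupus familiaris) for cytotoxicity, read by MTT assay, with a stated time of 24 h; a lower number here means that less compound is tolerated, a higher number that more compound is tolerated:
Compound 1 `N#CCCN(Cc1cccs1)S(=O)(=O)c1ccc(N)cc1`: > 207000 nM, a limit
Compound 2 `O=S(=O)(c1ccc(Br)cc1)N(Cc1cccs1)Cc1cccs1`: 81000 nM
Compound 3 `CCCN(Cc1cccs1)S(=O)(=O)c1ccc(Br)cc1`: > 178000 nM, a limit

Compound 3 stands at a limit and has no number of its own. Compound 1 also stands at a limit. Only compound 2 gives a number.

Compound 4 `O=C(O)CCN(Cc1cccs1)S(=O)(=O)c1ccc(Br)cc1` differs from compound 3 by carboxy in place of methyl on a saturated chain carbon, two bonds along the chain from a sulfonamide nitrogen.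

The nearest measured step is an at least 2.1-fold higher number from compound 2 to compound 3 (0.34 log units; beyond the scatter), with ethyl in place of thiophen-2-yl on a saturated chain carbon bound to a sulfonamide nitrogen. Going by the values given here, that step is modest and involves a different group, and no measured step changes the end of this chain. On that basis, no step beyond the scatter is expected in this assay, and a further limit is the likely result.

The estimated step is an at least 1.0-fold lower number from compound 3 to compound 4 (0.03 log units; that floor lies within the scatter). For compound 4 the estimate is 165000 nM, with an expected range of 90000 nM to 300000 nM.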

Compound 4, half-maximal cytotoxic concentration: > 164000 nM
Compound 4 ended at the assay's limit (the forecaster's own chance of this, stated with the estimate: 70%); the middle value does not contradict the limit.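

In this assay compound 4 gives a limit and no number of its own, so the propyl chain of compound 3 accepts 2-carboxyethyl without a number appearing: the limit of > 164000 nM in this assay, at which 1 of the 4 values shown sits.
The step from methyl to carboxy cannot be read, since compound 3 also stands at a limit. Going by these compounds alone, the one readable comparison is an at least 2.0-fold higher number from compound 2 to compound 4 (0.30 log units; that floor lies within the scatter), a floor that does not clear the scatter, whereas an at least 2.1-fold higher number from compound 2 to compound 3 (0.34 log units; beyond the scatter) does clear it; the data do not make this a real difference between the two chain ends.

Going by these compounds, whether carboxy at this position shifts the tolerated concentration at all stays open, since neither compound gives a number. On these data alone, how an amine at the end of this chain, or a longer chain ending in a carboxylic acid, would read in this assay also remains open.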